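The source may hold more compounds than are shown below. What is called first, only, known or untested is meant among the compounds shown, and "the series" means these compounds.

Measured in an ADME assay on microsomes from liver (Homo sapiens) for metabolic stability, read by LC-MS, using NADPH, with stated times of 5 min and 30 min, tested at 1 uM; a higher number here means faster removal of the compound, a lower number slower removal:
- Compound 1 `C[C@@H]1CC(=O)N(c2cnc(NCc3c(F)ccc4c3CCO4)n3cnnc23)C1`: < 3 mL.min-1.g-1
- Compound 2 `Cc1ncccc1-c1cnc(NCc2c(F)ccc3c2CCO3)c2ncc(=O)[nH]c12`: 21 mL.min-1.g-1
- Compound 3 `O=C1CCCN1c1cnc(NCc2c(F)ccc3c2CCO3)c2cn[nH]c(=O)c12`: 23 mL.min-1.g-1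

Compound 1 gives only a limit of the assay, not a number, at < 3 mL.min-1.g-1. Its place among the measured compounds is therefore (the limit of < 3 mL.min-1.g-1 in this assay, at which 1 of the 3 values shown sits).

Compound 4 `O=C(Nc1cnc(NCc2c(F)ccc3c2CCO3)n2cnnc12)c1cccnc1` keeps the core of compound 1 and carries ((pyridin-3-yl)carbonyl)amino in place of 4-methyl-2-oxopyrrolidin-1-yl on an aromatic carbon. A six-membered aromatic ring thus enters where a five-membered non-aromatic ring leaves.

Among the measured compounds shown here, no measured pair shows the effect of this change in this assay, so the expectation rests on indirect evidence. Compound 2, which has a different core, gives 21 mL.min-1.g-1. Compound 3, also on a different core, gives 23 mL.min-1.g-1. These two values suggest a modest upward move rather than a large one, though with wide uncertainty. The expected step is an at least 2.6-fold higher number from compound 1 to compound 4 (0.42 log units; beyond the scatter). For compound 4 the estimated value is 8 mL.min-1.g-1, with an expected range from 3 mL.min-1.g-1 to 25 mL.min-1.g-1.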

Compound 4, intrinsic clearance in microsomes: < 3 mL.min-1.g-1
Compound 4: only a limit was reported; the forecaster's own chance of this, stated with the estimate: 25%; middle value at least 2.6-fold (0.42 log units) away from the limit.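

In this assay compound 1 and compound 4 each give only a limit of the assay, so no step between them can be read: the limit of < 3 mL.min-1.g-1 in this assay, at which 2 of the 4 values shown sit.

The compounds shown leave open whether 4-methyl-2-oxopyrrolidin-1-yl and ((pyridin-3-yl)carbonyl)amino on the shared core differ at all in this assay.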